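Side-group swap from compound 3 to compound 4

The source may hold more compounds than are shown below. What is called first, only, known or untested is meant among the compounds shown, and "the series" means these compounds.

Measured so far in an ADME assay on microsomes from liver (Rattus norvegicus) for metabolic stability; on this read-out lower numbers stand for a shorter-lived compound and higher numbers for a longer-lived compound:
compound 1 `CC(C)C(c1ccc(-c2ccc3cccc(F)c3c2)[nH]c1=O)N1CCCCS1(=O)=O` gives 0.07 h
compound 2 `CC(C)C(c1ccc(-c2ccc3cccc(F)c3c2)[nH]c1=O)N1CCN/C1=N\C#N` gives 0.327 h
compound 3 `CC(C)C(Nc1nccs1)c1ccc(-c2ccc3cccc(F)c3c2)[nH]c1=O` gives 0.07 h

Compound 3 stands level with compound 1, and together they hold the lowest number of the three, with compound 2 the only one higher. The next step leads to compound 4 `CC(C)C(Cc1noc(=O)[nH]1)c1ccc(-c2ccc3cccc(F)c3c2)[nH]c1=O` and changes one group on the shared core: a group of 7 heavy atoms (3 carbon, 2 nitrogen, 2 oxygen; one five-membered aromatic ring with 3 hetero atoms) in place of a group of 6 heavy atoms (3 carbon, 2 nitrogen, 1 sulfur; one five-membered aromatic ring with 2 hetero atoms), on a saturated chain carbon bound to an aromatic carbon and a saturated chain carbon.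

Among the compounds with values here, three measured steps bear on this, all at the same place. They are a 4.7-fold higher number from compound 1 to compound 2 (0.67 log units; beyond the scatter), then no change at the digits printed from compound 1 to compound 3 (within the scatter), and a 4.7-fold lower number from compound 2 to compound 3 (0.67 log units; beyond the scatter). Swaps here have therefore moved this assay by a modest amount or not at all. The groups of compound 1 and compound 3 both carry sulfur, and the group of compound 2 carries none. The incoming group also carries none, but three compounds are a thin basis, so only part of the rise seen with compound 2 at 0.327 h is assumed to carry over. The expected change is small and upward, and it may not clear the scatter: a 2.0-fold higher number from compound 3 to compound 4 (0.30 log units; within the scatter) is the estimated step. For compound 4 the expected value is 0.14 h, with an estimated range from 0.06 h to 0.35 h.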

Compound 4, half-life: > 3 h
Compound 4: only a limit was reported; the forecaster's own chance of this, stated with the estimate: 5%; middle value at least 21-fold (1.33 log units) from the limit.
By their numbers in this assay, from the lowest: compounds 1 and 3 (each within the scatter of the next); then compound 2. At a limit, above all of these: compound 4.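

In this assay the reading of compound 4 is a limit of the assay and not a number: the limit of > 3 h in this assay, at which 1 of the 4 values shown sits. Within the data shown here, this position on the saturated chain carbon can therefore carry much larger moves than the earlier swaps showed, with an at least 42-fold higher number from compound 3 to compound 4 (1.63 log units; beyond the scatter) and an at least 42-fold higher number from compound 1 to compound 4 (1.63 log units; beyond the scatter) both large, and with an at least 9.1-fold higher number from compound 2 to compound 4 (0.96 log units; beyond the scatter) also taking the series past the one compound that had stood apart. Absence of sulfur does not settle the matter, as compound 2 and compound 4 both lack it and still differ beyond the scatter, while the counted hydrogen-bond donors, hydrogen-bond acceptors and net charge stay the same between the (1,3-thiazol-2-yl)amino group and the group that replaces it.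

As far as these compounds go, how far compound 4 lies beyond the limit stays open, and so does the size of its true step from each of the other compounds. Also open, from the compounds shown here alone, is whether the five-membered ring itself or the carbon link in place of the amino link carries the step, and whether a carboxylic acid or a primary amide on the same saturated chain carbon would read alike.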